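Working notes: sulfur for oxygen in compound 3

A few compounds are considered here, and "the series" means these few. Any claim that something is new, unique, unknown or untested is made for them only; others in the source may bear on it.

Measured in an ADME assay on MT4 cells (Homo sapiens) for cytotoxicity, read by MTT assay, with a stated time of 96 h (on this read-out higher numbers stand for lower toxicity in this test and lower numbers for higher toxicity in this test), so far:
- compound 1 `C/C(=N\NC(N)=S)c1ccc2[nH]c(-c3ccc(Cl)cc3)nc2c1` gives 2000 nM as its result
- compound 2 `C/C(=N\NC(N)=O)c1ccc2c(c1)nc(-c1ccc(Cl)cc1)n2C1CCCCC1` stands as "not determined" (no result reported) with no number

Compound 2 therefore offers no starting value in this assay for the step to compound 3 `C/C(=N\NC(N)=S)c1ccc2c(c1)nc(-c1ccc(Cl)cc1)n2C1CCCCC1` which remains unmeasured. Among the measured compounds shown here, the structural change is a group of 3 heavy atoms (1 carbon, 1 nitrogen, 1 sulfur; no ring) in place of a group of 3 heavy atoms (1 carbon, 1 nitrogen, 1 oxygen; no ring), on an amine nitrogen and no measured pair shows its effect. For the measured compounds named here, the only anchor is compound 1 at 2000 nM and a moderately higher value is expected for compound 3, meaning lower toxicity in this test, with wide uncertainty. For compound 3 the estimate is 8000 nM with an expected range from 2000 nM to 40000 nM on this basis.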

Compound 3, half-maximal cytotoxic concentration: 17000 nM
Estimate against measurement, compound 3: 2.1-fold (0.33 log units) below; low and high end bracket the measured number.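

In this assay, among the compounds shown here, cyclohexyl in place of hydrogen on an aromatic nitrogen gives the first readable step, an 8.5-fold higher number from compound 1 to compound 3 (0.93 log units; beyond the scatter), so this substitution goes with lower toxicity in this test. As far as these compounds go, the step from carbamoyl to its sulfur counterpart, from compound 2 to compound 3, cannot be read, and the effect of that exchange stays unknown. No supporting data bear on the reason for the cyclohexyl step. From the compounds shown here alone, whether methyl, a longer chain or a piperidine ring on that aromatic nitrogen would give a similar number remains open.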